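Moving the acid on a glutamate receptor modulator

This account rests on a few compounds, and the source may have more. Where it says the series, first, only, none or still open, it means among the compounds named here.

Measured in an assay on HEK293 cells for positive allosteric modulation of metabotropic glutamate receptor 2 (Rattus norvegicus), read by thallium flux, with a stated time of 2.5 min; on this read-out higher numbers stand for an effect only at larger amounts of compound and lower numbers for an effect already at smaller amounts:
- compound 1 `Cc1c(OCCCCOc2ccccc2C(=O)O)ccc(C(=O)CC2CCCC2)c1C` gives 2580 nM
- compound 2 `Cc1c(OCCCCOc2ccccc2C(=O)O)ccc(C(=O)CC2CCCC2)c1O` gives 335 nM
- compound 3 `Cc1c(OCCCCOc2ccccc2C(=O)O)ccc(C(=O)CC(C)C)c1C` gives 976 nM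

Among these three numbers compound 1 stands highest. The nearest is compound 3, with a 2.6-fold lower number from compound 1 to compound 3 (0.42 log units; beyond the scatter), and the furthest is compound 2, with a 7.7-fold lower number from compound 1 to compound 2 (0.89 log units; beyond the scatter).

Compound 4 `Cc1c(OCCCCOc2ccc(C(=O)O)c(Cl)c2)ccc(C(=O)CC2CCCC2)c1C` differs from compound 1 in one place: 4-carboxy-3-chlorophenyl in place of 2-carboxyphenyl on an oxygen on a saturated carbon. Neither of the two measured steps bears on this change. The step to compound 2 alters a substituent on the shared core, and the step to compound 3 alters the group bound to the carbonyl; both leave the carboxyphenyl end of the chain untouched. The data therefore give no guide to the size or direction of the step to compound 4, and the expectation rests on compound 1 alone. Compound 4 is accordingly expected to show a 1.2-fold higher number from compound 1 to compound 4 (0.07 log units; within the scatter) in this assay, with a wide range, and its value is estimated at 3000 nM (from 700 nM to 13000 nM).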

Compound 4, half-maximal effective concentration: 2420 nM
Beside the measured number, compound 4's estimate is 1.2-fold (0.09 log units) above it, and the stated range covers the measured number.
By their numbers in this assay, from the lowest: compound 2; then compound 3; then compounds 4 and 1 (each within the scatter of the next).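

Exchanging 2-carboxyphenyl for 4-carboxy-3-chlorophenyl on an oxygen on a saturated carbon gives a 1.1-fold lower number from compound 1 to compound 4 (0.03 log units; within the scatter) in this assay. The earlier steps shown here from compound 1 changed only the shared core or the group bound to the carbonyl, whereas this one shows that the aromatic ring at the end of the chain can carry its carboxylic acid in another arrangement, together with a chlorine, and compound 1 and compound 4 still cannot be told apart here. No measurement is available that explains this result.

The step alters the carboxylic acid's arrangement and adds chlorine at once, so a 4-carboxyphenyl group without the chlorine would be needed to separate the two. As far as these compounds go, it also remains open whether 4-carboxy-3-chlorophenyl would behave the same way alongside the hydroxy group of compound 2.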